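Urea analogues and cytotoxicity toward human skin fibroblasts

The compounds below may be only part of what the source reports. "The series", "measured", "known", "first", "only" and "open" are said of these compounds alone.

Three ureas built on a shared core have been tested in an ADME assay on BJ cells (Homo sapiens) for cytotoxicity, with a stated time of 72 h; a lower number here means that less compound is needed, a higher number that more compound is needed for the effect. Compound 1 `Cc1cc(NC(=O)Nc2ccc(C)c(Cl)c2)c2ccccc2n1` gives a value of > 25000 nM, which is a limit of the assay rather than a number. Compound 2 `Cc1cc(NC(=O)Nc2ncccc2C)c2ccccc2n1` likewise gives > 25000 nM, again a limit. Compound 3 `Cc1ccc(NC(=O)Nc2cc(C)nc3ccccc23)cc1` also reaches only > 25000 nM, a limit once more. All three values therefore sit at the limit of > 25000 nM in this assay, at which 3 of the 3 values shown sit, and compound 3 stands there with its two neighbours.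

Two single changes lead to compound 3. From compound 1 the change is a step that the two limits leave unreadable from compound 1 to compound 3. From compound 2 it is a step that the two limits leave unreadable from compound 2 to compound 3. Neither step can be sized, since both ends are limits.

Compound 4 `Cc1cc(NC(=O)Nc2ccc(N(C)C)cc2)c2ccccc2n1` differs from compound 3 by dimethylamino in place of methyl on an aromatic carbon. Within the data shown here, no measured step involves a dimethylamino group, so the comparison rests only on the fact that every change so far, including the exchange of chloro for hydrogen and of 3-methylpyridin-2-yl for 4-methylphenyl, has left the compounds at the limit in this assay. The expected step from compound 3 to compound 4 is therefore a number no higher from compound 3 to compound 4 (the limit leaves the size open), with no direction beyond the scatter. Compound 4 is estimated to give about 25000 nM in this assay, most likely again as a limit, within a range from 10000 nM to 60000 nM.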

Compound 4, half-maximal effective concentration: > 25000 nM
Compound 4 gave a limit, no number; the forecaster's own chance of this, stated with the estimate: 75%; the middle value lies on the limit itself.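

No size can be read for the step between compound 3 and compound 4, as both give a limit rather than a number: the limit of > 25000 nM in this assay, at which 4 of the 4 values shown sit.

The compounds shown leave open how much of any of them would be needed for the effect in this assay, and whether any change to the shared core would give a readable number.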